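A few compounds are considered here, and "the series" means these few. Any claim that something is new, unique, unknown or untested is made for them only; others in the source may bear on it.

Compounds measured in a functional assay on U-87MG ATCC cells (Homo sapiens) for cytotoxicity, read by MTT assay, with a stated time of 72 h; a lower number here means a stronger inhibitor, a higher number a weaker inhibitor:
- Compound 1, `CN(C)CCn1cnnc1-c1cc(Oc2ccc(NC(=O)N/N=C/c3cccc(O)c3)cc2F)ccn1`, gives > 100000 nM in this assay.
- Compound 2, `CN(C)CCn1cnnc1-c1cc(Oc2ccc(NC(=O)N/N=C/c3ccc(O)c(O)c3)cc2F)ccn1`, gives > 100000 nM in this assay.
- Compound 3, `Cc1cc(/C=N/NC(=O)Nc2ccc(Oc3ccnc(-c4nncn4CCN(C)C)c3)c(F)c2)cc(C)c1O`, gives 7710 nM in this assay.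

The value of compound 1, > 100000 nM, is a limit of this assay, not a number. The value of compound 2, > 100000 nM, is likewise a limit. For the measured compounds named here, compound 3, with 7710 nM, is the only member of the three with a measured number; the other two sit at the limit of > 100000 nM in this assay, at which 2 of the 3 values shown sit. The step that the two limits leave unreadable from compound 1 to compound 2 cannot be read. The steps of an at least 12-fold lower number from compound 1 to compound 3 (1.11 log units; beyond the scatter) and an at least 12-fold lower number from compound 2 to compound 3 (1.11 log units; beyond the scatter) are both large and both point to the 4-hydroxy-3,5-dimethylphenyl group as the only aryl on the carbon with a double bond to nitrogen that gives a readable number.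

Compound 4, `CN(C)CCn1cnnc1-c1cc(Oc2ccc(NC(=O)N/N=C/c3ccc(F)cc3F)cc2F)ccn1`, is not yet measured. It differs from compound 3 by 2,4-difluorophenyl in place of 4-hydroxy-3,5-dimethylphenyl on a carbon with a double bond to nitrogen. The 2,4-difluorophenyl group carries none of the features of the hydroxy-bearing aryls tried so far, so the measured steps bear on it only indirectly: every departure from the 4-hydroxy-3,5-dimethylphenyl group seen here has ended at the limit. A weaker result than compound 3 is therefore expected, with a fair chance that the assay again reports only a limit. Compound 4 is estimated at 25000 nM, between 5000 nM and 120000 nM, which means an expected step of a 3.2-fold higher number from compound 3 to compound 4 (0.51 log units; beyond the scatter).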

Compound 4, half-maximal inhibitory concentration: 1900 nM
Compound 4: the middle estimate sits 13-fold (1.12 log units) above what was measured, and the stated range ends above it.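

In this assay, a readable number at this position does not depend on a hydroxy-bearing aryl on the carbon with a double bond to nitrogen: 2,4-difluorophenyl, with 0 hydrogen-bond donors, in place of 4-hydroxy-3,5-dimethylphenyl gives a 4.1-fold lower number from compound 3 to compound 4 (0.61 log units; beyond the scatter), which makes compound 4 the strongest of the four in this series. The contrast with the other two aryls is larger, with an at least 52-fold lower number from compound 2 to compound 4 (1.72 log units; beyond the scatter) and an at least 52-fold lower number from compound 1 to compound 4 (1.72 log units; beyond the scatter), so the 2,4-difluorophenyl group stands clearly apart from both 3,4-dihydroxyphenyl and 3-hydroxyphenyl. Compound 1 and compound 2 each remain at a limit and not a number, and the step between them cannot be read: the limit of > 100000 nM in this assay, at which 2 of the 4 values shown sit.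

Compound 4 removes the hydroxy and methyl groups and brings in fluorine in one change, so the compounds shown do not separate the contribution of each. Also open, as far as these compounds go, is how plain phenyl, 4-fluorophenyl or 2,4-dichlorophenyl on the same carbon would compare with 2,4-difluorophenyl in this assay.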